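The source may report more compounds than this note shows. Statements on the series, on what has been measured and on what is new or still open speak of the compounds shown alone.

Compound 1 `C[C@H](NS(=O)(=O)c1cccc(C(=O)NO)c1)C(=O)Nc1ccccc1` gives 24200 nM in an assay on isolated protein for inhibition of histone deacetylase 8 (Homo sapiens), read by fluorescence, with stated times of 5 min and 30 min; on this read-out lower numbers stand for stronger inhibition and higher numbers for weaker inhibition.
Compound 2 `CC(C)[C@H](NS(=O)(=O)c1cccc(C(=O)NO)c1)C(=O)Nc1ccccc1` gives 33900 nM in this assay.

Of the two numbers, compound 2 holds the higher one, though the step of a 1.4-fold higher number from compound 1 to compound 2 (0.15 log units; within the scatter) is within the scatter, so the two compounds cannot be ordered. Compound 3 `O=C(NO)c1cccc(S(=O)(=O)N[C@H](C(=O)Nc2ccccc2)c2ccccc2)c1` is made from compound 2 by the change (phenyl in place of isopropyl on a saturated chain carbon bound to a carbonyl carbon and a sulfonamide nitrogen). Among the measured compounds shown here, the only step at this position, a 1.4-fold higher number from compound 1 to compound 2 (0.15 log units; within the scatter), was small, so a change at the same place is expected to move this assay little in either direction. Compound 3 is therefore estimated at 30000 nM, with a range from 12000 nM to 80000 nM, a step of a 1.1-fold lower number from compound 2 to compound 3 (0.05 log units; within the scatter) that is expected to stay within the scatter.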

Compound 3, half-maximal inhibitory concentration: 910 nM
Compound 3: the middle estimate sits 33-fold (1.52 log units) above what was measured, and the stated range ends above it.
By their numbers in this assay, from the lowest: compound 3; then compounds 1 and 2 (each within the scatter of the next).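

At the saturated chain carbon bound to a carbonyl carbon and a sulfonamide nitrogen, the read-out in this assay proves highly sensitive to the group: phenyl in place of isopropyl gives a 37-fold lower number from compound 2 to compound 3 (1.57 log units; beyond the scatter), and phenyl in place of methyl gives a 27-fold lower number from compound 1 to compound 3 (1.42 log units; beyond the scatter). Methyl and isopropyl could not be ordered, whereas phenyl sets compound 3 clearly apart from both. Nothing available explains this difference. The compounds shown leave open whether cyclohexyl would match phenyl here, and whether a phenyl carrying an amine or a carboxylic acid would keep the lower number.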